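This account rests on a few compounds, and the source may have more. Where it says the series, first, only, none or still open, it means among the compounds named here.

In an assay on CHO cells for displacement of a labelled ligand from transient receptor potential cation channel subfamily V member 1 (Rattus norvegicus) (on this read-out lower numbers stand for stronger inhibition and higher numbers for weaker inhibition), compound 1 `COc1cc(CNC(=S)NCC(COC(=O)C(C)(C)C)Cc2ccc(C)c(C)c2)c(Br)cc1O` gives 19.9 nM, and compound 2 `COc1cc(CNC(=S)NCC(COC(=O)C(C)(C)C)Cc2ccc(C)c(C)c2)c(I)cc1O` gives 18.9 nM. The change between them is iodo in place of bromo on an aromatic carbon, and it made a 1.1-fold lower number from compound 1 to compound 2 (0.02 log units; within the scatter). Compound 3 `COc1cc(CNC(=S)NC(CCc2ccc(C(C)(C)C)cc2)COC(=O)C(C)(C)C)cc(Br)c1O` gives 143 nM in this assay, the highest of the three numbers; how its core differs from that of compound 1 is not broken down here. Compound 4 `COc1cc(CNC(=S)NC(CCc2ccc(C(C)(C)C)cc2)COC(=O)C(C)(C)C)cc(I)c1O` has not yet been measured. It differs from compound 3 by iodo in place of bromo on an aromatic carbon. This is the same kind of change as from compound 1 to compound 2, but the surroundings differ: in compound 3 the carbon is ortho to a hydroxy group, meta to a large group and meta to a methoxy group, whereas in compound 1 it is ortho to a large group, meta to a hydroxy group and para to a methoxy group. Compound 4 is expected to make a 1.1-fold lower number from compound 3 to compound 4 (0.04 log units; within the scatter) in this assay, because a 1.1-fold lower number from compound 1 to compound 2 (0.02 log units; within the scatter) stayed within the scatter. Compound 4 is therefore estimated at 130 nM, between 60 nM and 300 nM.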

Compound 4, inhibition constant: 214 nM
The estimate for compound 4 lay 1.6-fold (0.22 log units) below the measured number, within the range that was stated.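

In this assay, iodo in place of bromo on an aromatic carbon gave a 1.5-fold higher number from compound 3 to compound 4 (0.18 log units; within the scatter), so this step, like the earlier one, stayed within the scatter. The two steps do not differ measurably across the two cores: the same change on two cores in this assay, a 1.1-fold lower number (0.02 log units; within the scatter) from compound 1 to compound 2 and a 1.5-fold higher number (0.18 log units; within the scatter) from compound 3 to compound 4, 1.6-fold (0.20 log units) apart, within the scatter of two such steps. This shows that the exchange of bromo for iodo had no readable effect on either core, even with different surroundings on the ring, but two pairs do not show that this would hold on other cores, nor do they separate the contribution of the core from that of the surroundings.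

The compounds shown leave open whether chloro or a plain hydrogen on this aromatic carbon would also stay within the scatter. They also leave open how a methyl group there would compare.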